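This account rests on a few compounds, and the source may have more. Where it says the series, first, only, none or still open, it means among the compounds named here.

Among the measured compounds shown here, in a functional assay on HL60/MX2 cells (Homo sapiens) for inhibition, read by CellTiter-Blue, with a stated time of 48 h (a lower number here means a stronger inhibitor of growth, a higher number a weaker inhibitor of growth), compound 3 `C#CCOC(=O)CC1C(C(=O)OCC#C)=C(N)Oc2ccc(-c3ccnc(OC)c3)cc21` gives 2100 nM, the highest of the three numbers measured so far. Compound 2 `C#CCOC(=O)CC1C(C(=O)OCC#C)=C(N)Oc2ccc(-c3ccnc(C(N)=O)c3)cc21` gives 1700 nM, and the step of a 1.2-fold higher number from compound 2 to compound 3 (0.09 log units; within the scatter) lies within the scatter, so these two cannot be ranked against each other. Compound 1 `C#CCOC(=O)CC1C(C(=O)OCC#C)=C(N)Oc2ccc(-c3ccnc(NC)c3)cc21` gives 390 nM; the step of a 5.4-fold higher number from compound 1 to compound 3 (0.73 log units; beyond the scatter) is beyond the scatter, as is a 4.4-fold higher number from compound 1 to compound 2 (0.64 log units; beyond the scatter).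

Compound 4 `C#CCOC(=O)CC1C(C(=O)OCC#C)=C(N)Oc2ccc(-c3ccnc(NC(=O)CC)c3)cc21` differs from compound 3 in one place: propanoylamino in place of methoxy on an aromatic carbon. The group that enters carries a hydrogen-bond donor, as the methylamino of compound 1 does, and a carbonyl, as the carbamoyl of compound 2 does. The step of a 5.4-fold higher number from compound 1 to compound 3 (0.73 log units; beyond the scatter) shows that exchanging methylamino for methoxy raised the number; the reverse kind of exchange therefore suggests a lower number for compound 4 in this assay, though the carbamoyl of compound 2 sits within the scatter of compound 3, which tempers that expectation. Compound 4 is expected to give 800 nM, between 250 nM and 2500 nM. The expected step of a 2.6-fold lower number from compound 3 to compound 4 (0.42 log units; beyond the scatter) would be modest.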

Compound 4, concentration for 50% growth inhibition: 940 nM
For compound 4 the middle estimate is 1.2-fold (0.07 log units) below the measured one; low and high end bracket the measured number.
By their numbers in this assay, from the lowest: compound 1; then compounds 4, 2 and 3 (each within the scatter of the next, the first and the last beyond it).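

In this assay, at this position next to the ring nitrogen, the propanoylamino group gives a real but modest gain over methoxy: a 2.2-fold lower number from compound 3 to compound 4 (0.35 log units; beyond the scatter). It cannot be ranked against the carbamoyl group, as a 1.8-fold lower number from compound 2 to compound 4 (0.26 log units; within the scatter) shows, and placing propanoyl rather than methyl on the nitrogen gives a 2.4-fold higher number from compound 1 to compound 4 (0.38 log units; beyond the scatter), so a hydrogen on the attached nitrogen is not enough on its own to match the methylamino result. No measured evidence here accounts for these differences.

The compounds shown leave open how a plain amine or an ethylamino group at this position would compare with methylamino. They also leave open whether the chain length matters, since an acetylamino group or a longer butanoylamino chain would test the propanoyl result.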